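Replacing Ethyl with 3-Fluorophenyl on the Shared Core

A few compounds are considered here, and "the series" means these few. Any claim that something is new, unique, unknown or untested is made for them only; others in the source may bear on it.

Measured so far:
compound 1 `C=CCNc1nc(N)c(C(=O)N=C(N)N)nc1Cl`: 78%
compound 2 `CCCNc1nc(N)c(C(=O)N=C(N)N)nc1Cl`: 91%

In an assay for inhibition of acid-sensing ion channel 3 (Homo sapiens), read by patch clamp, tested at 20 uM (on this read-out higher numbers stand for more inhibition at the one concentration tested (going by the name of the read-out) and lower numbers for less inhibition), compound 2 stands highest of the two numbers, its nearest neighbour being compound 1, and the step of a number 13 percentage points higher from compound 1 to compound 2 (beyond the scatter) is modest. Compound 3 `NC(N)=NC(=O)c1nc(Cl)c(NCc2cccc(F)c2)nc1N` differs from compound 2 by 3-fluorophenyl in place of ethyl on a saturated chain carbon bound to a nitrogen on an aromatic ring. For the measured compounds named here, no measured step involves an aromatic ring entering at this place, so the one known step offers only a loose guide. Since compound 2 already gives 91% in this assay, compound 3 is expected to stay close to that number, with a step of a number 6 percentage points lower from compound 2 to compound 3 (within the scatter). The estimate for compound 3 is 85%, within 65% to 98%.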

Compound 3, a percentage reported as inhibition, at one concentration (the size of the read-out at that concentration, not a potency): 90%
Beside the measured number, compound 3's estimate is 5 percentage points below it; the range from low to high includes it.
By their numbers in this assay, from the lowest: compound 1; then compounds 3 and 2 (each within the scatter of the next).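

In this assay, a far larger group fits at this place on a saturated chain carbon bound to a nitrogen on an aromatic ring: swapping ethyl for 3-fluorophenyl, with its six-membered aromatic ring, gives a number 1 percentage points lower from compound 2 to compound 3 (within the scatter) and so leaves the reading unchanged within the scatter. The same group gives a number 12 percentage points higher from compound 1 to compound 3 (beyond the scatter) when it replaces vinyl, so compound 1 remains the one set apart. No measurement here explains why these groups behave this way. Going by these compounds, whether a plain phenyl, an amine or a carboxylic acid at this place would hold the reading stays open, and a reading at one concentration does not give potency.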